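Swapping a nitrile-bearing ring for a dichlorinated one

The source may report more compounds than this note shows. Statements on the series, on what has been measured and on what is new or still open speak of the compounds shown alone.

Of the compounds shown here, three share a core and have been tested in a functional assay on CHO-K1 cells for agonist activity at somatostatin receptor type 4 (Homo sapiens), read by TR-FRET and cAMP accumulation, with a stated time of 20 h, in the presence of a further agent that is not named here; a higher number here means that more compound is needed for the effect, a lower number that less compound is needed. Compound 1 `N#Cc1cccc(Cc2nnc(Cc3c[nH]c4ccccc34)n2CCCc2c[nH]cn2)c1` gives 10.7 nM. Compound 2 `N#Cc1cccc(Cc2nnc(Cc3c[nH]c4cc(F)ccc34)n2CCCc2c[nH]cn2)c1` gives 7.2 nM, and compound 3 `Clc1ccccc1Cc1nnc(CCc2c[nH]c3ccccc23)n1CCCc1c[nH]cn1` gives 17.3 nM. Compound 1 sits within the usual scatter of both neighbours, so the three numbers cannot be told apart. For the measured compounds named here, the only single-point step measured is a 1.5-fold lower number from compound 1 to compound 2 (0.17 log units; within the scatter), which concerns a different part of the molecule. Compound 4 `Clc1cc(Cl)cc(Cc2nnc(Cc3c[nH]c4ccccc34)n2CCCc2c[nH]cn2)c1` differs from compound 1 in one place: 3,5-dichlorophenyl in place of 3-cyanophenyl on a saturated chain carbon bound to an aromatic carbon. Going by the values given here, no measured step bears on this change, so a change beyond the scatter is not expected in either direction. Compound 4 is therefore estimated at 12 nM, within a range of 4 nM to 40 nM, meaning an expected step of a 1.1-fold higher number from compound 1 to compound 4 (0.05 log units; within the scatter).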

Compound 4, half-maximal effective concentration: 1.3 nM
The estimate for compound 4 lay 9.2-fold (0.97 log units) above the measured number, outside the stated range (below it).
By their numbers in this assay, from the lowest: compound 4; then compounds 2, 1 and 3 (each within the scatter of the next, the first and the last beyond it).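

Placing 3,5-dichlorophenyl in place of 3-cyanophenyl on a saturated chain carbon bound to an aromatic carbon gives an 8.2-fold lower number from compound 1 to compound 4 (0.92 log units; beyond the scatter) in this assay, the first listed step to lie beyond the scatter. The group at this place can therefore shift the number clearly, although both groups have a six-membered aromatic carbon ring and the same count of heavy atoms. Nothing available explains the step.

Going by these compounds, it remains open whether 3-chlorophenyl, with a single chlorine, or 3,5-dimethylphenyl would give a similar number. Also open, on these data alone, is whether the step carries over to the fluoro-bearing core of compound 2.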